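The compounds below may be only part of what the source reports. "The series", "measured", "known", "first", "only" and "open" are said of these compounds alone.

Three compounds have been measured in an ADME assay (liver) for pharmacokinetics, with Liver microsome (Rattus norvegicus) as the target, using microsomes; a lower number here means that the compound disappears faster, a higher number that the compound lasts longer:

- compound 1 `CCOc1cc(NC(=O)C2(NC(=O)c3ccc4c(C5CCCC5)c(-c5ncc(Cl)cn5)n(C)c4c3)CCC2)ccc1/C=C/C(=O)OCOP(=O)(O)OC(C)(C)C` gives 0.133 h
- compound 2 `CCOc1cc(NC(=O)C2(NC(=O)c3ccc4c(C5CCCC5)c(-c5ncc(Cl)cn5)n(C)c4c3)CCC2)ccc1/C=C/C(=O)OCOP(=O)(O)O` gives 0.15 h
- compound 3 `CCCOC(=O)/C=C/c1ccc(NC(=O)C2(NC(=O)c3ccc4c(C5CCCC5)c(-c5ncc(Cl)cn5)n(C)c4c3)CCC2)cc1OCC` gives 0.35 h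

Compound 1 has the lowest of the three numbers, although the gap to compound 2 is within the scatter, as a 1.1-fold higher number from compound 1 to compound 2 (0.05 log units; within the scatter) shows, so these two cannot be told apart. Compound 4 `CCOc1cc(NC(=O)C2(NC(=O)c3ccc4c(C5CCCC5)c(-c5ncc(Cl)cn5)n(C)c4c3)CCC2)ccc1/C=C/C(=O)OCC(=O)N1CCCC1` has not yet been measured in this assay. Compared with compound 1 it carries a group of 7 heavy atoms (5 carbon, 1 nitrogen, 1 oxygen; one five-membered non-aromatic ring with 1 hetero atom) in place of a group of 9 heavy atoms (4 carbon, 4 oxygen, 1 phosphorus; no ring), on a saturated chain carbon bound to an oxygen next to a carbonyl group.

Among the compounds with values here, two measured steps bear on this change, since both swap out the phosphorus-containing group at that same place for a small carbon group: a 2.6-fold higher number from compound 1 to compound 3 (0.42 log units; beyond the scatter) and a 2.3-fold higher number from compound 2 to compound 3 (0.37 log units; beyond the scatter). Both are modest rises beyond the scatter. Within the data shown here, the group entering compound 4 is larger than the one in compound 3 and contains a ring, so the data do not show exactly what to expect, but a modest rise in the same direction is the most reasonable expectation. Compound 4 is therefore expected to show a 1.9-fold higher number from compound 1 to compound 4 (0.27 log units; within the scatter). The estimated half-life for compound 4 is 0.25 h, with a likely range from 0.12 h to 0.5 h.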

Compound 4, half-life: 1.47 h
Compound 4: middle estimate off by 5.9-fold (0.77 log units), on the low side; the whole stated range lies below it.
By their numbers in this assay, from the lowest: compounds 1 and 2 (each within the scatter of the next); then compound 3; then compound 4.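

Within the data shown here, at this saturated chain carbon bound to an oxygen next to a carbonyl group, (pyrrolidin-1-yl)carbonyl brings a much longer half-life in this assay than the earlier compounds showed, with an 11-fold higher number from compound 1 to compound 4 (1.04 log units; beyond the scatter) and a 9.8-fold higher number from compound 2 to compound 4 (0.99 log units; beyond the scatter) when the phosphorus-containing groups leave. Removing phosphorus is not the whole story, since neither compound 3 nor compound 4 contains it and there is still a 4.2-fold higher number from compound 3 to compound 4 (0.62 log units; beyond the scatter) on going from ethyl to (pyrrolidin-1-yl)carbonyl. No measurement here explains why this group gives the longer half-life.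

The compounds shown do not separate the part played by the ring from that of the carbonyl and its nitrogen. A dimethylamino carbonyl group, which has no ring, or a piperidin-1-yl carbonyl group, with a six-membered ring, would address that question.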